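The source may report more compounds than this note shows. Statements on the series, on what has been measured and on what is new or still open speak of the compounds shown alone.

Compound 1 `CCc1nnc(O)n2c(C)nc(C)c12` belongs to a small group of compounds built on one shared core. In a functional assay for inhibition, with Homo sapiens as the target (on this read-out higher numbers stand for weaker inhibition and lower numbers for stronger inhibition), compound 1 gives > 48000 nM, which is a limit of the assay rather than a number. Compound 2 `Cc1nc(C)n2c(O)nncc12` differs from compound 1 by hydrogen in place of ethyl on an aromatic carbon. In this assay compound 2 gives > 48000 nM, again a limit of the assay and not a number. The step that the two limits leave unreadable from compound 1 to compound 2 therefore cannot be read in either direction. Both values sit at the same point, as the limit of > 48000 nM in this assay, at which 2 of the 2 values shown sit, shows, so compound 1 stands only at a limit, with no number that places it against any other compound.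

Compound 3 `CCc1nnc(O)n2c(CC)nc(C)c12` has not yet been measured. It differs from compound 1 by methyl in place of hydrogen on a saturated chain carbon bound to an aromatic carbon. Among the compounds with values here, no measured step touches that place, and the only known step that starts from compound 1 is unreadable. The step that the limit leaves unreadable from compound 1 to compound 3 is therefore expected to be small or absent. Compound 3 is estimated at 60000 nM, with a range from 20000 nM to 200000 nM in this assay, and is most likely to return a limit as well.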

Compound 3, half-maximal inhibitory concentration: 24000 nM
Estimate against measurement, compound 3: 2.5-fold (0.40 log units) above; measured number inside the range.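

Within the data shown here, compound 3 is the first compound here to give a real number rather than a limit in this assay. This shows that a change at this one place, methyl in place of hydrogen on a saturated chain carbon bound to an aromatic carbon, can bring the shared core into the range where the assay returns a number; cut one bond further out, the same change reads methyl to ethyl. The change is read as an at least 2.0-fold lower number from compound 1 to compound 3 (0.30 log units; that floor lies within the scatter), and only that floor is known: the true step may be larger, but the floor alone does not clear the usual scatter of repeated measurements, and compound 1 and compound 2 still have no number that would fix its size: the limit of > 48000 nM in this assay, at which 2 of the 3 values shown sit.

Going by these compounds, whether a longer chain at this place would lower the number further, and whether an amine or a carboxylic acid there would give a number at all, stays open. The step from compound 1 to compound 2 cannot be read, so the compounds shown also leave open what the ethyl on the aromatic carbon contributes.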